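From 4-aminophenyl to pyridin-2-yl on a shared core

The compounds below may be only part of what the source reports. "The series", "measured", "known", "first", "only" and "open" are said of these compounds alone.

Compound 1 `CC(C)(C)n1cc2c(n1)C(=O)CC1(CCN(C(=O)c3cc(-c4ccccc4)nc4ccccc34)CC1)O2` gives 1940 nM
Compound 2 `COc1ccc(-c2cc(C(=O)N3CCC4(CC3)CC(=O)c3nn(C(C)(C)C)cc3O4)c3ccccc3n2)cc1` gives 3740 nM
Compound 3 `CC(C)(C)n1cc2c(n1)C(=O)CC1(CCN(C(=O)c3cc(-c4ccc(N)cc4)nc4ccccc34)CC1)O2` gives 970 nM

All three values come from a functional assay on A549 cells (Homo sapiens) for inhibition, read by MTT assay, with a stated time of 72 h (on this read-out higher numbers stand for weaker inhibition and lower numbers for stronger inhibition), and compound 3 is the starting point here. The data show a 2.0-fold lower number from compound 1 to compound 3 (0.30 log units; within the scatter) and also a 3.9-fold lower number from compound 2 to compound 3 (0.59 log units; beyond the scatter) so compound 3 cannot be told apart from compound 1 but does separate from compound 2.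

The unmeasured compound 4 `CC(C)(C)n1cc2c(n1)C(=O)CC1(CCN(C(=O)c3cc(-c4ccccn4)nc4ccccc34)CC1)O2` carries pyridin-2-yl in place of 4-aminophenyl on an aromatic carbon next to the ring nitrogen pyridin-2-yl in place of 4-aminophenyl on an aromatic carbon and the rest of the molecule stays the same. Like compound 1, compound 4 has no amino group, so the most relevant step is a 2.0-fold lower number from compound 1 to compound 3 (0.30 log units; within the scatter) read backwards. The step of a 1.9-fold higher number from compound 1 to compound 2 (0.29 log units; within the scatter) adds that a different substituent on this ring changed little. Going by the values given here, no measured compound has a nitrogen in this ring, which leaves that part of the change uncertain.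

The step expected in this assay is a 2.0-fold higher number from compound 3 to compound 4 (0.29 log units; within the scatter) and so a small one, towards a higher number. For compound 4 the estimated value is 1900 nM with an expected range from 700 nM to 5000 nM in this assay for now.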

Compound 4, half-maximal inhibitory concentration: 7720 nM
Estimate against measurement, compound 4: 4.1-fold (0.61 log units) below, and the stated range ends below it.
By their numbers in this assay, from the lowest: compounds 3, 1 and 2 (each within the scatter of the next, the first and the last beyond it); then compound 4.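

Pyridin-2-yl is the first group at this position to separate from plain phenyl: in this assay there is a 4.0-fold higher number from compound 1 to compound 4 (0.60 log units; beyond the scatter), whereas the methoxy and amino changes on the phenyl ring stayed within the scatter of compound 1. The substituted rings separate from it as well, with a 2.1-fold higher number from compound 2 to compound 4 (0.31 log units; beyond the scatter) and an 8.0-fold higher number from compound 3 to compound 4 (0.90 log units; beyond the scatter), which makes compound 4 the weakest inhibitor of the four. This position is therefore not indifferent to the ring it carries, and a nitrogen within that ring counts for more here than either substituent on the phenyl ring.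

Nothing measured here explains why this change weakens inhibition. Still open, as far as these compounds go, is whether pyridin-3-yl or pyridin-4-yl would behave like pyridin-2-yl, and whether an amino group on the pyridine ring would bring the number back towards that of compound 3.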